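Morpholin-4-yl for ethyl(isopropyl)amino on the sulfonyl sulfur

The compounds below may be only part of what the source reports. "The series", "measured", "known", "first", "only" and "open" are said of these compounds alone.

Working notes on the series. Compound 1 `CCN(CC)S(=O)(=O)c1ccc(S(=O)(=O)N2CCC[C@@H](C(=O)N[C@@H]3CCN(C(=O)OC(C)(C)C)C3)C2)cc1` carries a carbamate-protected amide side chain; in a functional assay on MIA PaCa-2 cells (Homo sapiens) for inhibition, read by MTT assay, with a stated time of 3 days (on this read-out lower numbers stand for stronger inhibition and higher numbers for weaker inhibition), compound 1 gives only a limit of > 10000 nM and no number. Compound 2 `CCOC(=O)[C@@H]1CCCN(S(=O)(=O)c2ccc(S(=O)(=O)N(CC)C(C)C)cc2)C1` is the ethyl ester on the same core; in this assay compound 2 likewise gives only a limit of > 10000 nM and not a number. Going by the values given here, both results sit at the limit of > 10000 nM in this assay, at which 2 of the 2 values shown sit, so no step between measured compounds can be read, and compound 2 stands at that limit alongside compound 1 with nothing to rank it against.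

Compound 3 `CCOC(=O)[C@@H]1CCCN(S(=O)(=O)c2ccc(S(=O)(=O)N3CCOCC3)cc2)C1` differs from compound 2 in a single place: morpholin-4-yl in place of ethyl(isopropyl)amino on a sulfonyl sulfur. Among the compounds with values here, no measured step covers this exchange, and the two values seen so far give no direction, only that both fall at the limit. The expectation for this assay is therefore no step beyond the scatter, a step that the limit leaves unreadable from compound 2 to compound 3, because the limit of > 10000 nM in this assay, at which 2 of the 2 values shown sit, places every value recorded so far at the limit. Compound 3 is estimated at 15000 nM, with a range from 5000 nM to 50000 nM, and most likely again reported only as a limit.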

Compound 3, half-maximal inhibitory concentration: > 10000 nM
Compound 3 ended at the assay's limit (the forecaster's own chance of this, stated with the estimate: 85%); the middle value is on the limit's open side.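

In this assay compound 3 gives > 10000 nM, a limit and not a number. No step from compound 2 to compound 3 can be read, because both stand at the same limit: the limit of > 10000 nM in this assay, at which 3 of the 3 values shown sit.

The compounds shown leave open how morpholin-4-yl and ethyl(isopropyl)amino rank against each other, and whether any compound on the shared core gives a number in this assay.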